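A few compounds are considered here, and "the series" means these few. Any claim that something is new, unique, unknown or untested is made for them only; others in the source may bear on it.

Measured compounds:
- compound 1, `O=C1COCCN1c1ccc(/N=C\c2c[nH]c3ccccc23)cc1`: in a functional assay on BV-2 cells (Mus musculus) for inhibition, read by ELISA, tested at 10 uM (on this read-out lower numbers stand for a stronger effect and higher numbers for a weaker effect at the one concentration tested), compound 1 gives 91.2%
- compound 2, `Cc1ccc(S(=O)(=O)n2cc(/C=N\c3ccc(N4CCOCC4=O)cc3)c3ccccc32)cc1`: compound 2 gives 101%
- compound 3, `O=C1COCCN1c1ccc(/N=C\c2cn(C(=O)c3ccccc3)c3ccccc23)cc1`: compound 3 gives 258%

Compound 3 stands highest of the three. Its step up from compound 2 is a number 157 percentage points higher from compound 2 to compound 3 (beyond the scatter) and from compound 1 it is a number 166.8 percentage points higher from compound 1 to compound 3 (beyond the scatter), both beyond the scatter, while compound 1 and compound 2 sit within the scatter of each other, a number 9.8 percentage points higher from compound 1 to compound 2 (within the scatter).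

Compound 4, `O=C1COCCN1c1ccc(/N=C\c2cn(Cc3ccccc3)c3ccccc23)cc1`, differs from compound 3 in one place: benzyl in place of benzoyl on an aromatic nitrogen. The measured steps that bear on this change are the two that put benzoyl onto this nitrogen, both large and upward. Among the compounds with values here, no measured step shows what benzyl does there; the compounds with hydrogen or with (4-methylphenyl)sulfonyl on that nitrogen give the low end. Taking benzoyl away is therefore expected to bring the number down, by an estimated a number 118 percentage points lower from compound 3 to compound 4 (beyond the scatter), with wide uncertainty since benzyl keeps one six-membered aromatic ring but no carbonyl. Compound 4 is expected to give about 140%, within a range from 85% to 230%.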

Compound 4, a percentage reported as activity, at one concentration (the size of the read-out at that concentration, not a potency): 266%
The estimate for compound 4 lay 126 percentage points below the measured number; measured number outside the range, above it.
By their numbers in this assay, from the lowest: compounds 1 and 2 (each within the scatter of the next); then compounds 3 and 4 (each within the scatter of the next).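

In this assay, the carbonyl of benzoyl proves unnecessary for the high number on this aromatic nitrogen: benzyl in place of benzoyl gives a number 8 percentage points higher from compound 3 to compound 4 (within the scatter), so the two groups cannot be told apart here. Benzyl also separates clearly from the two low compounds, with a number 174.8 percentage points higher from compound 1 to compound 4 (beyond the scatter) against hydrogen and a number 165 percentage points higher from compound 2 to compound 4 (beyond the scatter) against (4-methylphenyl)sulfonyl, which shows that a six-membered aromatic ring on this nitrogen does not by itself bring the high number, since compound 2 carries one and stays low. Nothing available explains why these groups differ in this way. The compounds shown leave open how a small methyl group or a longer chain ending in an amine would behave on this nitrogen. Such groups would show whether a ring is needed there at all.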